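The compounds below may be only part of what the source reports. "The series", "measured", "known", "first", "only" and "open" are said of these compounds alone.

Measured so far:
- compound 1 `CC(=O)Nc1cccc(NC(=O)COc2ccc3c(=O)ccoc3c2)c1` gives 136 nM
- compound 2 `O=C(COc1ccc2c(=O)ccoc2c1)Nc1cccc(NC(=O)c2ccccc2)c1` gives 16 nM
- compound 3 `CCc1ccc(C(=O)Nc2cccc(NC(=O)COc3ccc4c(=O)ccoc4c3)c2)cc1` gives 24 nM

In an assay on isolated protein for inhibition of Rho-associated protein kinase 2 (Homo sapiens), read by scintillation counting, radiometric assay and 33P incorporation, with a stated time of 40 min, in the presence of a further agent that is not named here (on this read-out lower numbers stand for stronger inhibition and higher numbers for weaker inhibition), compound 1 stands highest of the three numbers; the nearest is compound 3 and the furthest is compound 2. Compound 4 `CC(C)(C)c1cc(C(=O)Nc2cccc(NC(=O)COc3ccc4c(=O)ccoc4c3)c2)no1` differs from compound 1 by 5-(tert-butyl)-1,2-oxazol-3-yl in place of methyl on a carbonyl carbon. Among the compounds with values here, two measured steps bear on this change: both exchange methyl for an aromatic group on the same carbonyl carbon, and both gave lower numbers, an 8.5-fold lower number from compound 1 to compound 2 (0.93 log units; beyond the scatter) and a 5.7-fold lower number from compound 1 to compound 3 (0.75 log units; beyond the scatter). Between the two aromatic groups, a 1.5-fold higher number from compound 2 to compound 3 (0.18 log units; within the scatter). A five-membered heteroaromatic ring has not been tried here, so its reading is less certain, but a lower number than compound 1 is expected for compound 4, roughly a 4.5-fold lower number from compound 1 to compound 4 (0.66 log units; beyond the scatter). Compound 4 is therefore estimated at 30 nM, expected to fall between 10 nM and 90 nM.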

Compound 4, half-maximal inhibitory concentration: 5 nM
Estimate against measurement, compound 4: 6.0-fold (0.78 log units) above; the measured number lies below the stated range.
By their numbers in this assay, from the lowest: compound 4; then compounds 2 and 3 (each within the scatter of the next); then compound 1.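

In this assay, the carbonyl carbon accepts a larger gain than phenyl or 4-ethylphenyl had shown, with a 27-fold lower number from compound 1 to compound 4 (1.43 log units; beyond the scatter). The choice of group here also proves to matter, which the earlier aromatic pair left unseen: 5-(tert-butyl)-1,2-oxazol-3-yl gives a 3.2-fold lower number from compound 2 to compound 4 (0.51 log units; beyond the scatter) and a 4.8-fold lower number from compound 3 to compound 4 (0.68 log units; beyond the scatter). Nothing at hand explains this gain.

Whether it belongs to the ring or to the tert-butyl stays open: the compounds shown include neither 4-tert-butylphenyl nor 5-methyl-1,2-oxazol-3-yl. Going by these compounds, how an amine or a carboxylic acid on that ring would read is also open.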